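A few compounds are considered here, and "the series" means these few. Any claim that something is new, unique, unknown or untested is made for them only; others in the source may bear on it.

Compound 1 `COc1ccc(-c2cccc(S(=O)(=O)N3CCC(N4CCC(C)CC4)CC3)c2)cc1`: > 5000 nM, a limit of the assay.
Compound 2 `Cc1cc(C)c(S(=O)(=O)N2CCC(N3CCCCCC3)CC2)c(C)c1`: > 5000 nM, a limit of the assay.
Compound 3 `CC1CCN(C2CCN(S(=O)(=O)c3ccc(OCc4ccccc4)cc3)CC2)CC1`: > 5000 nM, a limit of the assay.

Of the compounds shown here, three have been tested so far in an ADME assay on HCT-116 cells (Homo sapiens) for cytotoxicity, read by CellTiter-Glo, with a stated time of 72 h; on this read-out higher numbers stand for weaker inhibition and lower numbers for stronger inhibition. For compound 1 the result is only a limit and not a number. Compound 2 likewise gives only a limit. Compound 3 also gives only a limit. Compound 1 therefore stands where every measured compound stands, at the limit of > 5000 nM in this assay, at which 3 of the 3 values shown sit, and no ordering among the three can be drawn from these results.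

Compound 4 `CC1CCN(C2CCN(S(=O)(=O)c3cccc(-c4ccccc4)c3)CC2)CC1` has not yet been measured in this assay. It differs from compound 1 in one place: hydrogen in place of methoxy on an aromatic carbon.

Among the compounds with values here, no step between measured compounds is available to gauge such a change. The step that the limit leaves unreadable from compound 1 to compound 4 is expected to be none beyond the usual scatter, because compound 1 itself sits at the limit of > 5000 nM in this assay, at which 3 of the 3 values shown sit, together with the other measured compounds. Compound 4 is thus estimated at 8000 nM, within a range from 4000 nM to 20000 nM, and the assay is expected most likely to report only a limit again.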

Compound 4, half-maximal inhibitory concentration: > 5000 nM
Compound 4: no number, only a limit (the forecaster's own chance of this, stated with the estimate: 75%); the middle value is on the limit's open side.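

Compound 1 and compound 4 both give only a limit of the assay, so no step can be read between them, because neither value is a number: the limit of > 5000 nM in this assay, at which 4 of the 4 values shown sit.

The compounds shown leave open what replacing 4-methoxyphenyl with phenyl does to this read-out, and how the four compare.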